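Replacing 3-Methylphenyl with Oxan-4-yl on the Amide Carbonyl

The compounds below may be only part of what the source reports. "The series", "measured", "known", "first", "only" and "open" are said of these compounds alone.

In a toxicity assay on THP-1 cells (Homo sapiens) for inhibition (a lower number here means that less compound is tolerated, a higher number that more compound is tolerated), compound 1 `COc1ccc(-c2cnc(NC(=O)c3cnc[nH]3)n2C)cc1` gives > 100000 nM, which is a limit and not a number. Compound 2 `COc1ccc(-c2cnc(NC(=O)c3cccc(C)c3)n2C)cc1` gives > 100000 nM, which is also a limit. The record so far is the limit of > 100000 nM in this assay, at which 2 of the 2 values shown sit, so compound 2 has no exact value. Compound 3 `COc1ccc(-c2cnc(NC(=O)C3CCOCC3)n2C)cc1` has not yet been measured. It carries oxan-4-yl in place of 3-methylphenyl on a carbonyl carbon. For the measured compounds named here, the only measured step at this place is a step that the two limits leave unreadable from compound 1 to compound 2, and it offers no size to carry over. No step beyond the scatter is therefore expected in this assay, in either direction. The estimated change is a number no higher from compound 2 to compound 3 (the limit leaves the size open). Compound 3 is expected to give 100000 nM, with an estimated range from 50000 nM to 200000 nM. A further limit rather than a number is the likeliest report.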

Compound 3, half-maximal cytotoxic concentration: > 100000 nM
Compound 3: only a limit was reported (the forecaster's own chance of this, stated with the estimate: 90%); the middle value lies on the limit itself.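

In this assay no step among compound 1, compound 2 and compound 3 can be read, as each result is a limit and not a number: the limit of > 100000 nM in this assay, at which 3 of the 3 values shown sit.

The compounds shown leave open the actual half-maximal cytotoxic concentration of each compound, and whether the group on the carbonyl carbon affects it at all.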